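The source may report more compounds than this note shows. Statements on the series, on what has been measured and on what is new or still open speak of the compounds shown alone.

Of the compounds shown here, three built on one shared core have been measured. Compound 1 `c1ccc(-c2cn3ccnc3c(-c3ccc4ncn(C5CCCCC5)c4c3)n2)cc1` gives 63.9% in a functional assay on OVCAR-8 cells (Homo sapiens) for inhibition, read by sulforhodamine B assay, with a stated time of 48 h, tested at 10 uM; a lower number here means less inhibition, a higher number more inhibition at the concentration tested (going by the name of the read-out). Compound 2 `COc1ccc(-c2cn3ccnc3c(-c3ccc4ncn(C5CCCCC5)c4c3)n2)cc1` gives 71.2%, a step of a number 7.3 percentage points higher from compound 1 to compound 2 (within the scatter). Compound 3 `Clc1ccc(-c2cn3ccnc3c(-c3ccc4ncn(C5CCCCC5)c4c3)n2)cc1` gives 3.78%, the lowest of the three, reached through steps of a number 60.1 percentage points lower from compound 1 to compound 3 (beyond the scatter) and a number 67.4 percentage points lower from compound 2 to compound 3 (beyond the scatter). Compound 4 `Brc1ccc(-c2cn3ccnc3c(-c3ccc4ncn(C5CCCCC5)c4c3)n2)cc1` is not yet measured and differs from compound 3 by bromo in place of chloro on an aromatic carbon. Going by the values given here, no measured step compares these two halogens directly, so the large fall seen on going to chloro is the only guide, and both are halogens of the same kind of position. Compound 4 is therefore expected to stay low, with an expected step of a number 6.2 percentage points higher from compound 3 to compound 4 (within the scatter). The estimate for compound 4 is 10%, in a range from 0% to 35%.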

Compound 4, a percentage reported as inhibition, at one concentration (the size of the read-out at that concentration, not a potency): 13.2%
The estimate for compound 4 lay 3.2 percentage points below the measured number; low and high end bracket the measured number.
By their numbers in this assay, from the lowest: compounds 3 and 4 (each within the scatter of the next); then compounds 1 and 2 (each within the scatter of the next).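

In this assay, the change from 4-chlorophenyl to 4-bromophenyl gives a number 9.4 percentage points higher from compound 3 to compound 4 (within the scatter), so these two halogens cannot be told apart here. The low reading therefore does not belong to chloro alone, as bromo also gives a number 50.7 percentage points lower from compound 1 to compound 4 (beyond the scatter) and a number 58 percentage points lower from compound 2 to compound 4 (beyond the scatter). Nothing at hand explains why either halogen reads so low. Still open, as far as these compounds go, is whether fluoro, an amine or a carboxylic acid in this place would read like the halogens or like methoxy. Also open, from the compounds shown here alone, is whether the same drop would appear with a different group in place of the cyclohexyl ring.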